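Removing the benzyl group from compound 3

The source may report more compounds than this note shows. Statements on the series, on what has been measured and on what is new or still open speak of the compounds shown alone.

In an ADME assay on Vero cells (Chlorocebus sabaeus) for cytotoxicity, read by resazurin assay, with a stated time of 72 h (on this read-out higher numbers stand for lower toxicity in this test and lower numbers for higher toxicity in this test), compound 1 `CC(=O)OC[C@H]1O[C@@H](CC(=O)/C=C2\C(=O)N(Cc3ccccc3)c3ccccc32)[C@H](OC(C)=O)[C@@H](OC(C)=O)[C@@H]1OC(C)=O` gives 71200 nM as its value, compound 2 `CC(=O)OC[C@H]1O[C@@H](CC(=O)/C=C2\C(=O)N(Cc3ccc(F)cc3)c3ccccc32)[C@H](OC(C)=O)[C@@H](OC(C)=O)[C@@H]1OC(C)=O` gives 119000 nM as its value and compound 3 `CC(=O)OC[C@H]1O[C@@H](CC(=O)/C=C2\C(=O)N(Cc3ccccc3)c3ccc(Cl)cc32)[C@H](OC(C)=O)[C@@H](OC(C)=O)[C@@H]1OC(C)=O` gives 91200 nM as its value, which lies within the scatter of both others. Compound 4 `CC(=O)OC[C@H]1O[C@@H](CC(=O)/C=C2\C(=O)Nc3ccc(Cl)cc32)[C@H](OC(C)=O)[C@@H](OC(C)=O)[C@@H]1OC(C)=O` carries hydrogen in place of benzyl on an amide-type nitrogen in a ring relative to compound 3. For the measured compounds named here, two measured steps bear on this only loosely: (a 1.7-fold higher number from compound 1 to compound 2 (0.22 log units; within the scatter)) and (a 1.3-fold higher number from compound 1 to compound 3 (0.11 log units; within the scatter)). Both are aromatic substitutions, and neither removes a benzyl group, so direct evidence is lacking. The expected step in this assay is a 1.3-fold higher number from compound 3 to compound 4 (0.12 log units; within the scatter) and so none beyond the scatter. For compound 4 the estimated value is 120000 nM with an expected range from 55000 nM to 260000 nM as a wide allowance.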

Compound 4, half-maximal cytotoxic concentration: 122000 nM
Estimate against measurement, compound 4: 1.0-fold (0.01 log units) below, and the stated range covers the measured number.
By their numbers in this assay, from the lowest: compounds 1, 3, 2 and 4 (each within the scatter of the next).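

In this assay, for the compounds shown here, the change on the amide-type nitrogen is the first outside the aromatic substitutions: benzyl leaves and hydrogen enters, giving a 1.3-fold higher number from compound 3 to compound 4 (0.13 log units; within the scatter). With the chloro substituent of compound 3 in place, the whole benzyl group can therefore go from this nitrogen without a step beyond the scatter. Nothing available accounts for this result.

On these data alone, it remains open whether a longer alkyl chain, or a chain ending in an amine or a carboxylic acid, on this nitrogen would stay within the scatter. As far as these compounds go, it also remains open whether hydrogen in place of benzyl gives a similar step on compound 1, which lacks the chloro group.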